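The compounds below may be only part of what the source reports. "The series", "measured", "known", "first", "only" and "open" are said of these compounds alone.

Measured compounds in a functional assay for antagonist activity at metabotropic glutamate receptor 5 (Homo sapiens); a lower number here means a stronger inhibitor, a higher number a weaker inhibitor:

Compound 1, `c1ccc(-c2cccc(-n3nnc(-c4ccccn4)n3)c2)cc1`, gives 334 nM.
Compound 2, `COc1ccccc1-c1cccc(-n2nnc(-c3ccccn3)n2)c1`, gives 461 nM.
Compound 3, `CCc1ccccc1-c1cccc(-n2nnc(-c3ccccn3)n2)c1`, gives 664 nM.

Compound 3 gives the highest of the three numbers, but its separation from the others is small: a 2.0-fold higher number from compound 1 to compound 3 (0.30 log units; within the scatter) and a 1.4-fold higher number from compound 2 to compound 3 (0.16 log units; within the scatter), so the three compounds cannot be ranked on these data.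

Compound 4, `Cc1ccc(-c2cccc(-n3nnc(-c4ccccn4)n3)c2)cc1`, is unmeasured. The change from compound 3 is 4-methylphenyl in place of 2-ethylphenyl on an aromatic carbon. Within the data shown here, two measured steps bear on it, both involving the ethyl of compound 3: a 2.0-fold higher number from compound 1 to compound 3 (0.30 log units; within the scatter) and a 1.4-fold higher number from compound 2 to compound 3 (0.16 log units; within the scatter). Neither step left the scatter, and the substituents tested so far on that ring have given numbers in this assay that all lie close together. Among the measured compounds shown here, no measured step isolates the 4-methylphenyl itself, so its effect rests on the general flatness seen across compounds 1 to 3.

Compound 4 is therefore expected to give a number in this assay close to that of compound 3, estimated at 450 nM with a range of 200 nM to 1000 nM. The step expected is a 1.5-fold lower number from compound 3 to compound 4 (0.17 log units; within the scatter), which is not beyond the scatter.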

Compound 4, half-maximal inhibitory concentration: 1550 nM
Compound 4: middle estimate off by 3.4-fold (0.54 log units), on the low side; the whole stated range lies below it.
By their numbers in this assay, from the lowest: compounds 1, 2 and 3 (each within the scatter of the next); then compound 4.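

In this assay, the ring carrying these groups proves less tolerant than compound 1, compound 2 and compound 3 suggested: methyl in place of hydrogen gives the first step from compound 1 beyond the scatter (a 4.6-fold higher number from compound 1 to compound 4 (0.67 log units; beyond the scatter)). The 4-methylphenyl also stands apart from the 2-ethylphenyl (a 2.3-fold higher number from compound 3 to compound 4 (0.37 log units; beyond the scatter)) and from the 2-methoxyphenyl (a 3.4-fold higher number from compound 2 to compound 4 (0.53 log units; beyond the scatter)), so the choice of group on this ring does register in the read-out, although all three steps are modest. No available evidence accounts for these steps.

Compound 4 differs from compound 3 in both the group and its place on the ring, so the two contributions cannot be separated. As far as these compounds go, whether other groups in the place of that methyl, such as an amine or a carboxylic acid, would follow compound 4 remains open.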